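This account rests on a few compounds, and the source may have more. Where it says the series, first, only, none or still open, it means among the compounds named here.

Of the compounds shown here, three built on one shared core have been tested in an ADME assay on HEK293 cells (Homo sapiens) for inhibition, read by MTT assay, with a stated time of 48 h, tested at 25 uM; a higher number here means more inhibition at the concentration tested (going by the name of the read-out), a lower number less inhibition. Compound 1 `COc1ccccc1-n1cc(COc2ccc3c(c2)CCC3)nn1` carries a 2-methoxyphenyl group on the five-membered ring, and in this assay compound 1 gives 19.8%. Compound 2 `O=[N+]([O-])c1cccc(-n2cc(COc3ccc4c(c3)CCC4)nn2)c1` carries a nitrophenyl group instead, and in this assay compound 2 gives "not determined" (no result reported). Compound 3 `Cc1ccc(-n2cc(COc3ccc4c(c3)CCC4)nn2)c(C)c1` carries a 2,4-dimethylphenyl group, and in this assay compound 3 gives 19.9%. So compound 3 and compound 1 sit within the scatter of each other, and there is no other number to set against them.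

Going by these compounds, compound 4 `COc1cccc(-n2cc(COc3ccc4c(c3)CCC4)nn2)c1` is still untested. Compared with compound 3, (3-methoxyphenyl in place of 2,4-dimethylphenyl on an aromatic nitrogen).

For the measured compounds named here, only one measured step bears on this change: swapping one phenyl substituent for another gave a number 0.1 percentage points higher from compound 1 to compound 3 (within the scatter), a change that lies within the scatter. The move to compound 4 is of the same kind, so the step of a number 0.1 percentage points higher from compound 3 to compound 4 (within the scatter) is expected to stay within the scatter as well. For compound 4 the estimate in this assay is 20%, with a range from 8% to 32%.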

Compound 4, a percentage reported as inhibition, at one concentration (the size of the read-out at that concentration, not a potency): 25.8%
Estimate against measurement, compound 4: 5.8 percentage points below; low and high end bracket the measured number.
By their numbers in this assay, from the lowest: compounds 1, 3 and 4 (each within the scatter of the next).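

In this assay, for the compounds shown here, a number 5.9 percentage points higher from compound 3 to compound 4 (within the scatter) and a number 6 percentage points higher from compound 1 to compound 4 (within the scatter) are wider than the only step available before, yet both remain within the usual scatter. Three different substituted phenyl groups on the aromatic nitrogen, including two placements of a methoxy group, therefore give numbers that cannot be told apart, so neither the 3-methoxyphenyl swap nor the shift of the methoxy group shows a real effect here. No measured information explains the values of these compounds.

Going by these compounds, it remains open whether a phenyl group carrying an amine or a carboxylic acid, or a longer chain in place of the phenyl group, would move the number beyond the scatter. On these data alone, the effect of changes to the shared core also remains open.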